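Removing a Methyl Group from a Naphthyl-Bearing Core

The source may report more compounds than this note shows. Statements on the series, on what has been measured and on what is new or still open speak of the compounds shown alone.

Of the compounds shown here, two sharing one core have been tested in a functional assay on PC-3 cells (Homo sapiens) for antiproliferative activity; on this read-out lower numbers stand for stronger inhibition of growth and higher numbers for weaker inhibition of growth. Compound 1 `Cc1cnc2nc(-c3ccc4ccccc4c3)cc(O)c2c1` gives 407 nM in this assay. Compound 2 `Cc1ccnc2nc(-c3ccc4ccccc4c3)cc(O)c12`, which carries its methyl at another spot on the core, gives 1380 nM, the higher of the two numbers and thus the weaker growth inhibitor of the pair.

The next compound, compound 3 `Oc1cc(-c2ccc3ccccc3c2)nc2ncccc12`, is the bare core without any methyl group. Compared with compound 2 the change is hydrogen in place of methyl on an aromatic carbon. For the measured compounds named here, no step of this kind has been measured on this core, so the outcome is open. Since removal of a single methyl group usually shifts a read-out only modestly, the step from compound 2 to compound 3 is expected to be small, a 1.6-fold lower number from compound 2 to compound 3 (0.21 log units; within the scatter), and possibly not beyond the scatter. Compound 3 is therefore estimated to give about 850 nM in this assay, with a likely range from 300 nM to 2500 nM.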

Compound 3, concentration for 50% growth inhibition: 10500 nM
For compound 3 the middle estimate is 12-fold (1.09 log units) below the measured one, outside the stated range (above it).
By their numbers in this assay, from the lowest: compound 1; then compound 2; then compound 3.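

Hydrogen in place of methyl on an aromatic carbon, opposite the ring nitrogen, gives a 7.6-fold higher number from compound 2 to compound 3 (0.88 log units; beyond the scatter) in this assay and shows that even a single carbon atom at this position can matter strongly on this core. The same exchange, read against the other methyl-bearing compound, gives a 26-fold higher number from compound 1 to compound 3 (1.41 log units; beyond the scatter) and is the larger of the two steps, so both compounds with a methyl group inhibit growth more strongly than the bare core, though by different amounts. No measurement at hand explains why the methyl group matters so much here.

The compounds shown leave open whether an ethyl group, a methoxy group or an amine on the same aromatic carbon would match methyl or surpass it. Also open, on these data alone, is whether the two methyl groups, placed together on one core, would add to each other's effect.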